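A few compounds are considered here, and "the series" means these few. Any claim that something is new, unique, unknown or untested is made for them only; others in the source may bear on it.

Three compounds have been measured in a functional assay on MCF7 cells (Homo sapiens) for antiproliferative activity, read by MTT assay, with a stated time of 72 h; on this read-out lower numbers stand for stronger inhibition and higher numbers for weaker inhibition:

Compound 1 `Cc1ccc(S(=O)(=O)NCc2cn(C[C@H](O)[C@H]3OC(=O)C(OCc4ccccc4)=C3OCc3ccccc3)nn2)cc1`: 6400 nM
Compound 2 `C[Si](C)(C)c1cn(C[C@H](O)[C@H]2OC(=O)C(OCc3ccccc3)=C2OCc2ccccc2)nn1`: 12100 nM
Compound 3 `Cc1ccc(-c2cn(C[C@H](O)[C@H]3OC(=O)C(OCc4ccccc4)=C3OCc3ccccc3)nn2)cc1`: > 100000 nM, which is a limit of the assay and not a number.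

Compound 3 therefore stands at the edge of what the assay can report (the limit of > 100000 nM in this assay, at which 1 of the 3 values shown sits). Against the two compounds with numbers, the steps are an at least 15-fold higher number from compound 1 to compound 3 (1.19 log units; beyond the scatter) and an at least 8.2-fold higher number from compound 2 to compound 3 (0.91 log units; beyond the scatter), both beyond the scatter, so compound 3 is the weakest of the three.

Compound 4 `CCCCCc1ccc(-c2cn(C[C@H](O)[C@H]3OC(=O)C(OCc4ccccc4)=C3OCc3ccccc3)nn2)cc1` differs from compound 3 only by butyl in place of hydrogen on a saturated chain carbon bound to an aromatic carbon. Within the data shown here, none of the measured steps touches this saturated chain carbon; all of them swap the whole group on the aromatic carbon. They thus give no direct guide for lengthening the chain, and they leave compound 3 at a limit.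

The expectation is that compound 4 remains similarly weak, with the step of a number no higher from compound 3 to compound 4 (the limit leaves the size open) expected to show nothing beyond the scatter. Compound 4 is therefore estimated at 100000 nM, within a range from 30000 nM to 300000 nM.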

Compound 4, half-maximal inhibitory concentration: 9010 nM
Compound 4: the middle estimate sits 11-fold (1.05 log units) above what was measured, and the stated range ends above it.
By their numbers in this assay, from the lowest: compounds 1, 4 and 2 (each within the scatter of the next). At a limit, above all of these: compound 3.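

On the saturated chain carbon bound to an aromatic carbon, butyl in place of hydrogen (methyl to pentyl, cut one bond further out) gives an at least 11-fold lower number from compound 3 to compound 4 (1.04 log units; beyond the scatter), so in this assay a change of chain alone, with no swap of the whole group on the aromatic carbon, separates a limit from a measurable value. The 4-pentylphenyl group also brings compound 4 level with the two compounds that carry other groups, with a 1.3-fold lower number from compound 2 to compound 4 (0.13 log units; within the scatter) and a 1.4-fold higher number from compound 1 to compound 4 (0.15 log units; within the scatter). The true size of the first step stays unknown, as compound 3 has a limit of the assay and not a number: the limit of > 100000 nM in this assay, at which 1 of the 4 values shown sits.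

As far as these compounds go, what remains open is how activity follows chain length, for instance with propyl or a longer chain such as octyl. Also open, from the compounds shown here alone, is whether a chain carrying an amine would keep this activity.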